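A few compounds are considered here, and "the series" means these few. Any claim that something is new, unique, unknown or untested is made for them only; others in the source may bear on it.

Measured so far in an assay on HEK293 cells for agonist activity at Bile acid receptor (Homo sapiens), read by a luciferase reporter; on this read-out lower numbers stand for an effect already at smaller amounts and higher numbers for an effect only at larger amounts of compound: compound 1 `CC(C)OC(=O)C1CN(C(=O)c2cccc(Cl)c2)CC(C)(C)c2cc(C#N)[nH]c21` gives 1300 nM; compound 2 `CC(C)OC(=O)C1CN(C(=O)c2cccc(F)c2)CC(C)(C)c2cc(C#N)[nH]c21` gives 1300 nM.

Going by the values given here, compound 2 stands level with compound 1, the only other measured compound; the step from compound 1 to compound 2 was no change at the digits printed from compound 1 to compound 2 (within the scatter). Compound 3 `CC(C)OC(=O)C1CN(C(=O)c2ccc(F)cc2)CC(C)(C)c2cc(C#N)[nH]c21` differs from compound 2 by 4-fluorophenyl in place of 3-fluorophenyl on a carbonyl carbon. Among the compounds with values here, no measured step moves the fluorine itself; the one step on this aromatic ring, a halogen exchange, stayed within the scatter. For compound 3 no step beyond the scatter is therefore expected in this assay, no change at the digits printed from compound 2 to compound 3 (within the scatter). Compound 3 is estimated at 1300 nM, with a range of 500 nM to 3500 nM.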

Compound 3, half-maximal effective concentration in the Bile acid receptor assay: 640 nM
For compound 3 the middle estimate is 2.0-fold (0.31 log units) above the measured one; the measured number falls inside the stated range.
By their numbers in the Bile acid receptor assay, from the lowest: compound 3; then compounds 1 and 2 (each within the scatter of the next).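

Where the fluorine sits on the phenyl ring matters more than the halogen exchange did: in the Bile acid receptor assay the change to 4-fluorophenyl gives a 2.0-fold lower number from compound 2 to compound 3 (0.31 log units; beyond the scatter). The same ring also gives a 2.0-fold lower number from compound 1 to compound 3 (0.31 log units; beyond the scatter), so both 3-halophenyl amides fall on the same side of this modest step. In a physicochemical assay for solubility, at pH 7.4 (on this read-out lower numbers stand for lower solubility and higher numbers for higher solubility), compound 2 gives > 100 ug/mL, which is a limit of the assay. In the physicochemical assay compound 3 gives > 100 ug/mL, which is also a limit of the assay. In the physicochemical assay the step from compound 2 to compound 3 cannot be read, as both values are limits of the assay: the limit of > 100 ug/mL in the physicochemical assay, at which 2 of the 2 values shown sit.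

Open, as far as these compounds go, is whether an amine or a methoxy group in place of the fluorine moves the number further. Also open, from the compounds shown here alone, is whether a carboxylic acid in place of the isopropyl ester keeps it.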